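A Smaller Side Chain on a Series Without Measured Inhibition

The source may hold more compounds than are shown below. What is called first, only, known or untested is meant among the compounds shown, and "the series" means these compounds.

Compound 2 `C=CCONC(=O)CN1C(=O)S/C(=C\c2cccc(C(=O)N[C@@H](CC(C)C)C(=O)OC)c2)C1=O` is one of three close relatives tested in a functional assay on RAW264.7 cells (Mus musculus) for inhibition, read by microscopy and resazurin assay, with a stated time of 72 h; a higher number here means a weaker inhibitor, a lower number a stronger inhibitor. In this assay compound 2 reaches only the limit > 128000 nM, a limit of the assay and not a number. Compound 1 `C=CCONC(=O)CN1C(=O)S/C(=C\c2ccc(C(=O)N[C@@H](CC(C)C)C(=O)OC)cc2)C1=O` gives the same limit > 128000 nM in this assay. Compound 3 `COC(=O)[C@H](CC(C)C)NC(=O)c1cccc(/C=C2\SC(=O)N(CC(=O)NOCc3ccccc3)C2=O)c1` likewise stops at the limit > 128000 nM in this assay. Going by the values given here, the only comparable step, phenyl in place of vinyl on a saturated chain carbon bound to an oxygen on an unsaturated carbon, is a step that the two limits leave unreadable from compound 2 to compound 3, since all values sit at the boundary described by the limit of > 128000 nM in this assay, at which 3 of the 3 values shown sit. Compound 4 `C=CCONC(=O)CN1C(=O)S/C(=C\c2cccc(C(=O)N[C@H](C(=O)OC)C(C)C)c2)C1=O` has not yet been measured. It differs from compound 2 by isopropyl in place of isobutyl on a saturated chain carbon bound to an amide-type nitrogen and a carbonyl carbon. Among the compounds with values here, no measured step offers a readable size, so the expected step that the limit leaves unreadable from compound 2 to compound 4 is none beyond the scatter, most likely ending again at a limit. Compound 4 is therefore estimated at 200000 nM, ranging from 100000 nM to 600000 nM in this assay.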

Compound 4, half-maximal inhibitory concentration: > 128000 nM
Compound 4: a limit, no number; the forecaster's own chance of this, stated with the estimate: 85%; the middle value does not contradict the limit.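

Compound 2 and compound 4 both end at a limit, not a number, so no step can be read between them: the limit of > 128000 nM in this assay, at which 4 of the 4 values shown sit. The compounds shown leave open whether any close relative gives a measurable inhibitory value in this assay, and whether the side chain matters there.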